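The compounds below may be only part of what the source reports. "The series", "measured", "known", "first", "only" and "open" are said of these compounds alone.

In an ADME assay on MCF-10A cells (Homo sapiens) for inhibition, with a stated time of 48 h (on this read-out lower numbers stand for stronger inhibition and higher numbers for weaker inhibition), compound 1 `O=C(Nc1ccc(I)cc1)N1CCC[C@H]1c1nc(-c2ccccc2)no1` gives > 50000 nM, which is a limit of the assay rather than a number.
In this assay compound 2 `N#Cc1ccc(NC(=O)N2CCC[C@H]2c2nc(-c3ccccc3)no2)cc1` gives > 50000 nM, again only a limit.
In this assay compound 3 `O=C(Nc1ccc(Cl)cc1)N1CCC[C@H]1c1nc(-c2ccc(I)cc2)no1` gives > 50000 nM, also only a limit.

Compound 1 and compound 2 differ by cyano in place of iodo on an aromatic carbon, and the step that the two limits leave unreadable from compound 1 to compound 2 cannot be sized because of the limit of > 50000 nM in this assay, at which 3 of the 3 values shown sit. Compound 4 `N#Cc1ccc(-c2noc([C@@H]3CCCN3C(=O)Nc3ccc(Cl)cc3)n2)cc1` has not been measured; it differs from compound 3 by cyano in place of iodo on an aromatic carbon, the same change at the same place on the ring, while the difference between the core of compound 1 and the core of compound 3 is not broken down here. Because (the limit of > 50000 nM in this assay, at which 3 of the 3 values shown sit), the earlier step offers no guide to size, and compound 3 itself already sits at that limit. Compound 4 is therefore expected to remain beyond the limit too, a step that the limit leaves unreadable from compound 3 to compound 4. The estimate for compound 4 is 60000 nM.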

Compound 4, half-maximal inhibitory concentration: > 50000 nM
Compound 4 was reported as a limit; the forecaster's own chance of this, stated with the estimate: 85%; the middle value does not contradict the limit.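

Compound 3 and compound 4 are both reported only as limits, so no size can be read for the step between them: the limit of > 50000 nM in this assay, at which 4 of the 4 values shown sit.

The compounds shown leave open what actual number any of them would reach in this assay.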